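A few compounds are considered here, and "the series" means these few. Any claim that something is new, unique, unknown or untested is made for them only; others in the source may bear on it.

Measured compounds in a functional assay on CWR22R cells (Homo sapiens) for inhibition, with a stated time of 120 h, tested at 10 uM; on this read-out lower numbers stand for less inhibition and higher numbers for more inhibition at the one concentration tested (going by the name of the read-out):
- compound 1, `Cc1n[nH]c2ccc(-c3nc4cnc(N5CCN(C)CC5)cn4c3Nc3ccccc3F)cc12`: 0%
- compound 2, `Cc1n[nH]c2ccc(-c3nc4cnc(N5CCN(C)CC5)cn4c3Nc3cccc(F)c3)cc12`: 5.41%
- compound 3, `Cc1cc(Br)ccc1Nc1c(-c2ccc3[nH]nc(C)c3c2)nc2cnc(N3CCN(C)CC3)cn12`: "not determined" (no result reported)

Within the data shown here, compound 3 stands nowhere on the numbers: in this assay compound 3 gives "not determined" (no result reported), so it has no value to start from, and no step can be measured from it. Compound 4, `Cc1n[nH]c2ccc(-c3nc4cnc(N5CCN(C)CC5)cn4c3Nc3cc(Cl)ccc3Cl)cc12`, is the unmeasured compound. The change from compound 3 is 2,5-dichlorophenyl in place of 4-bromo-2-methylphenyl on a nitrogen on an aromatic ring, an exchange of one substituted phenyl for another on the nitrogen that joins the shared core to the aryl group.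

Among the measured compounds shown here, only one measured step touches the same part of the molecule: a number 5.4 percentage points higher from compound 1 to compound 2 (within the scatter). That step also swaps one substituted phenyl for another on the same nitrogen, and it lies within the scatter, with both compound 1 and compound 2 close to zero. Nothing here shows that a change on this aryl group moves the read-out beyond the scatter. Compound 4 is therefore expected to sit near the same low level, at about 3%, with a range from 0% to 15%.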

Compound 4, a percentage reported as inhibition, at one concentration (the size of the read-out at that concentration, not a potency): 3.8%
Compound 4: middle estimate off by 0.8 percentage points, on the low side; measured number inside the range.
By their numbers in this assay, from the lowest: compounds 1, 4 and 2 (each within the scatter of the next).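

Notes on the aryl group on the nitrogen, read in this assay: 2,5-dichlorophenyl in place of 3-fluorophenyl gives a number 1.6 percentage points lower from compound 2 to compound 4 (within the scatter), and 2,5-dichlorophenyl in place of 2-fluorophenyl gives a number 3.8 percentage points higher from compound 1 to compound 4 (within the scatter). Among these compounds, the earlier comparison covered only two fluorophenyl groups; a chlorine-bearing phenyl now joins them with no separation among the three, while any step from compound 3 cannot be read, as compound 3 has no result. No measurement on hand accounts for the read-out staying at this level.

Still open, on these data alone, is whether an aryl group on this nitrogen carrying an amine or a carboxylic acid would separate from these three compounds. Also open, as far as these compounds go, is whether a non-aromatic group there, such as cyclohexyl, would do so.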